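A few compounds are considered here, and "the series" means these few. Any claim that something is new, unique, unknown or untested is made for them only; others in the source may bear on it.

Measured so far in a functional assay on HL-60 cells (Homo sapiens) for antiproliferative activity, read by MTT assay; on this read-out higher numbers stand for weaker inhibition and lower numbers for stronger inhibition:

compound 1 `CC(=O)O[C@@H]1[C@@H](OCc2ccccc2)[C@H](OCc2ccccc2)[C@@H](COCc2ccccc2)O[C@H]1Cc1ccccc1` gives "not active" (no number reported)
compound 2 `O[C@@H]1[C@@H](OCc2ccccc2)[C@H](OCc2ccccc2)[C@@H](COCc2ccccc2)O[C@H]1Cc1ccccc1` gives 8700 nM

Compound 1 has no single number to stand on: in this assay compound 1 is recorded only as "not active" (no number reported) and nothing more. Compound 3 `C=CC[C@@H]1O[C@H](COCc2ccccc2)[C@@H](OCc2ccccc2)[C@H](OCc2ccccc2)[C@H]1OC(C)=O` departs from compound 1 at one place: vinyl in place of phenyl on a saturated chain carbon bound to a saturated ring carbon and in words vinyl in place of phenyl on a saturated chain carbon bound to a saturated ring carbon, which also reads as benzyl to allyl. Going by the values given here, no step between measured compounds is available to scale this change. Because compound 1 gives "not active" (no number reported) with no number, no clear gain is expected in this assay and a result without activity is quite possible. Any number that does appear is expected on the weaker side of compound 2 at 8700 nM in the same read-out. If a number is reported, compound 3 is estimated at 20000 nM within a range from 6000 nM to 60000 nM as expected bounds.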

Compound 3, half-maximal inhibitory concentration: 26900 nM
The estimate for compound 3 lay 1.3-fold (0.13 log units) below the measured number; the range from low to high includes it.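

In this assay, going by these compounds alone, compound 3 gives 26900 nM and compound 1 is recorded as "not active" (no number reported); no step between compound 1 and compound 3 can be read. The compounds shown leave open how far benzyl to allyl shifts the number on its own. No evidence bears on this result.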